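Swapping Chloro for Methylsulfonyl on a Shared Amide Core

The compounds below may be only part of what the source reports. "The series", "measured", "known", "first", "only" and "open" are said of these compounds alone.

Three measured compounds share one amide core and differ only in the group on the six-membered carbon ring. Compound 1 `CC(Cl)/C=C/C(=O)N(Cc1ccc(C#N)cc1)CC(C)C` carries a cyano group, compound 2 `CC(Cl)/C=C/C(=O)N(Cc1ccc(C(F)(F)F)cc1)CC(C)C` a trifluoromethyl group and compound 3 `CC(Cl)/C=C/C(=O)N(Cc1ccc(Cl)cc1)CC(C)C` a chloro group. In an assay on isolated protein (Gossypium hirsutum) for inhibition of protoporphyrinogen oxidase 1, chloroplastic (Arabidopsis thaliana) (on this read-out lower numbers stand for stronger inhibition and higher numbers for weaker inhibition), compound 1 gives 63100 nM, compound 2 gives 5010 nM and compound 3 gives 2510 nM. Compound 3 holds the lowest number of the three, but its gap to compound 2 is small: a 2.0-fold lower number from compound 2 to compound 3 (0.30 log units; within the scatter). Against compound 1 the steps are clear, with a 25-fold lower number from compound 1 to compound 3 (1.40 log units; beyond the scatter) and a 13-fold lower number from compound 1 to compound 2 (1.10 log units; beyond the scatter).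

Compound 4 `CC(Cl)/C=C/C(=O)N(Cc1ccc(S(C)(=O)=O)cc1)CC(C)C` alters one place on compound 3: methylsulfonyl in place of chloro on an aromatic carbon. Within the data shown here, no measured step includes methylsulfonyl, so guidance is indirect. The two steps that reach chloro differ in size: replacing cyano was large, replacing trifluoromethyl stayed within the scatter. Leaving chloro for a group unlike either one is therefore expected to move the number upward rather than down, with wide uncertainty. For compound 4 in this assay the estimated value is 30000 nM, with a range from 5000 nM to 150000 nM, meaning an expected step of a 12-fold higher number from compound 3 to compound 4 (1.08 log units; beyond the scatter).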

Compound 4, half-maximal inhibitory concentration: > 100000 nM
Compound 4 was reported as a limit; the forecaster's own chance of this, stated with the estimate: 15%; middle value at least 3.3-fold (0.52 log units) from the limit.
By their numbers in this assay, from the lowest: compounds 3 and 2 (each within the scatter of the next); then compound 1. At a limit, above all of these: compound 4.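

Compound 4 is reported in this assay only as a limit, not as a number: the limit of > 100000 nM in this assay, at which 1 of the 4 values shown sits. Even so, the change is clearly visible, with an at least 39-fold higher number from compound 3 to compound 4 (1.60 log units; beyond the scatter) and an at least 19-fold higher number from compound 2 to compound 4 (1.30 log units; beyond the scatter), so the earlier picture of cyano as the only group at this position far from chloro and trifluoromethyl no longer holds, and methylsulfonyl is a second such group. Against cyano itself the comparison says much less, because the only available figure is a floor, an at least 1.5-fold higher number from compound 1 to compound 4 (0.19 log units; that floor lies within the scatter), and that floor settles no order between those two compounds.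

The compounds shown leave open how weak compound 4 really is, and whether what separates chloro and trifluoromethyl from cyano and methylsulfonyl is size, the hydrogen-bond acceptors counted on methylsulfonyl, or something else. A methoxy group, an amine or a carboxylic acid on the same aromatic carbon, or a bare hydrogen there, would give further points for judging how narrow the range of tolerated groups at this position is.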